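Swapping an Aminooxetane for a Carbamoyl Group

The source may hold more compounds than are shown below. What is called first, only, known or untested is meant among the compounds shown, and "the series" means these compounds.

Of the compounds shown here, three have been tested in an ADME assay on HEp-2 cells (Homo sapiens) for cytotoxicity, read by CCK-8 assay, with a stated time of 5 days; on this read-out higher numbers stand for lower toxicity in this test and lower numbers for higher toxicity in this test. Compound 1 `Cc1ccc2nc(N3CCCc4ccc(F)cc4C3)cc(NCC3(N)COC3)c2c1` reaches only a limit of the assay, > 100000 nM, and no number. Compound 2 `NCCNc1cc(N2CCCc3ccccc3C2)nc2cccc(Cl)c12` gives 23000 nM in this assay. Compound 3 `NCCNc1cc(N2CCCc3ccccc3C2)nc2ccc(C(F)(F)F)cc12` gives 6700 nM in this assay. Compound 1 thus sits at the edge of the range shown, (the limit of > 100000 nM in this assay, at which 1 of the 3 values shown sits). Compound 4 `Cc1ccc2nc(N3CCCc4ccc(F)cc4C3)cc(NCC(N)=O)c2c1` has not been measured yet and differs from compound 1 in one place: carbamoyl in place of 3-aminooxetan-3-yl on a saturated chain carbon bound to a nitrogen on an aromatic ring. Going by the values given here, no step between two measured compounds touches this change, so the expectation rests on compound 1 alone. The step from compound 1 to compound 4 is expected to be a number no higher from compound 1 to compound 4 (the limit leaves the size open), none beyond the scatter. Compound 4 is therefore expected to give 100000 nM in this assay, between 40000 nM and 300000 nM, most likely again only as a limit.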

Compound 4, half-maximal cytotoxic concentration: 22000 nM
For compound 4 the middle estimate is 4.5-fold (0.66 log units) above the measured one; the whole stated range lies above it.
By their numbers in this assay, from the lowest: compound 3; then compounds 4 and 2 (each within the scatter of the next). At a limit, above all of these: compound 1.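

At this place on the chain, the group decides whether a number can be read at all in this assay: carbamoyl in place of 3-aminooxetan-3-yl gives an at least 4.5-fold lower number from compound 1 to compound 4 (0.65 log units; beyond the scatter). Going by these compounds alone, this is the first sign that a change here, on the core of compound 1, moves the read-out towards higher toxicity in this test. The true size of the step stays open, because compound 1 stands at a limit of the assay: the limit of > 100000 nM in this assay, at which 1 of the 4 values shown sits.

On these data alone, how a carboxylic acid or a methyl amide at this place would read remains open, as does whether the same swap gives a similar step on another core.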